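Adding a Second Chloro Group to an Unmeasured Analogue

The source may report more compounds than this note shows. Statements on the series, on what has been measured and on what is new or still open speak of the compounds shown alone.

Compound 1 `Nc1sc2c(c1-c1nc3ccccc3s1)CCCC2` is the simplest member of this small set, and in an ADME assay on HeLa cells (Homo sapiens) for cytotoxicity, read by MTT assay, with a stated time of 72 h (on this read-out higher numbers stand for lower toxicity in this test and lower numbers for higher toxicity in this test), compound 1 gives 475 ug/mL. Compound 2 `Nc1sc2c(c1-c1nc3cc(Cl)ccc3s1)CCCC2` differs from it by a single change, (chloro in place of hydrogen on an aromatic carbon), and in this assay compound 2 gives 107 ug/mL. That step, a 4.4-fold lower number from compound 1 to compound 2 (0.65 log units; beyond the scatter), makes compound 2 the more toxic of the pair in this test. Compound 3 `Clc1ccccc1/C=N/c1sc2c(c1-c1nc3ccccc3s1)CCC2` is built on a different core; how its core differs from the core of compound 1 is not broken down here. In this assay compound 3 gives 138 ug/mL, which stands close to compound 2 and well apart from compound 1.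

Compound 4 `Clc1ccc(/C=N/c2sc3c(c2-c2nc4ccccc4s2)CCC3)c(Cl)c1` has not been measured. It differs from compound 3 by chloro in place of hydrogen on an aromatic carbon, the same kind of change as from compound 1 to compound 2 but not the same: there the chloro entered a ring that is part of a fused or bridged system of two rings, meta to a fused ring and para to a fused ring, whereas here it enters a ring of carbon only, meta to a chloro group and para to a large group. Since the earlier change gave a 4.4-fold lower number from compound 1 to compound 2 (0.65 log units; beyond the scatter), a lowering is expected, though a smaller one given the different surroundings, amounting to an estimated 2.0-fold lower number from compound 3 to compound 4 (0.29 log units; within the scatter). Compound 4 is thus expected to give about 70 ug/mL, most likely between 30 ug/mL and 160 ug/mL.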

Compound 4, half-maximal cytotoxic concentration: 345 ug/mL
The estimate for compound 4 lay 4.9-fold (0.69 log units) below the measured number; the measured number lies above the stated range.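

Adding the chloro group that turns 2-chlorophenyl into 2,4-dichlorophenyl gave a 2.5-fold higher number from compound 3 to compound 4 (0.40 log units; beyond the scatter), so in this assay compound 4 comes out as the less toxic of this pair. The earlier step went the other way, and in this series a chloro group in place of an aromatic hydrogen therefore cannot simply be carried from one core to another with its effect intact: the same change on two cores in this assay, a 4.4-fold lower number (0.65 log units; beyond the scatter) from compound 1 to compound 2 and a 2.5-fold higher number (0.40 log units; beyond the scatter) from compound 3 to compound 4, 11-fold (1.05 log units) apart, beyond the scatter of two such steps.

Going by these compounds alone, this does not show why the two steps differ, since the chloro group entered a different ring in each case, and core and place of the change remain tangled, with only one pair on each side.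

From the compounds shown here alone, it remains open whether a chloro group entering at the place it took in compound 2 would also lower the number on the core of compound 3. Also open, going by these compounds, is whether a fluoro, methyl or methoxy group at the new place on compound 4's ring of carbon only would follow chloro.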